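Swapping the Alcohol Arm for a Methoxyphenyl Ring

The compounds below may be only part of what the source reports. "The series", "measured", "known", "first", "only" and "open" are said of these compounds alone.

Going by the values given here, compound 2 `CC(C)(O)c1cn(Cc2nnc(-c3cc(S(N)(=O)=O)c(SCc4ccccc4)cc3Cl)o2)nn1` gives 68000 nM in a functional assay on HeLa cells (Homo sapiens) for cytotoxicity, read by MTT assay, with a stated time of 72 h (a lower number here means a stronger inhibitor, a higher number a weaker inhibitor), the lower of the two numbers measured so far. Its companion compound 1 `CCOC(=O)c1cn(Cc2nnc(-c3cc(S(N)(=O)=O)c(SCc4ccccc4)cc3Cl)o2)nn1` gives 122000 nM in this assay, and the change a 1.8-fold lower number from compound 1 to compound 2 (0.25 log units; within the scatter) sits inside the usual scatter. Compound 3 `COc1ccc(-c2cn(Cc3nnc(-c4cc(S(N)(=O)=O)c(SCc5ccccc5)cc4Cl)o3)nn2)cc1` differs from compound 2 at the same position: 4-methoxyphenyl in place of 1-hydroxy-1-methylethyl on an aromatic carbon. Among the compounds with values here, the only step that bears on this position was that small one, so compound 3 is expected to move no further than the scatter, in either direction, with a 1.4-fold lower number from compound 2 to compound 3 (0.13 log units; within the scatter) expected. The estimate for compound 3 is 50000 nM, within 15000 nM to 150000 nM.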

Compound 3, half-maximal inhibitory concentration: 68000 nM
Estimate against measurement, compound 3: 1.4-fold (0.13 log units) below, and the stated range covers the measured number.
By their numbers in this assay, from the lowest: compounds 2, 3 and 1 (each within the scatter of the next).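

Putting 4-methoxyphenyl in place of 1-hydroxy-1-methylethyl adds a six-membered aromatic ring and removes the hydrogen-bond donor, yet the step shows no change at the digits printed from compound 2 to compound 3 (within the scatter) on this aromatic carbon. Against ethoxycarbonyl, the step of a 1.8-fold lower number from compound 1 to compound 3 (0.25 log units; within the scatter) is also small. Three different groups here now lie within the scatter of one another, which a single pair could not show. Nothing available explains this lack of separation. From the compounds shown here alone, whether an amine or a carboxylic acid at this position would separate from these three remains open.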